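The source may report more compounds than this note shows. Statements on the series, on what has been measured and on what is new or still open speak of the compounds shown alone.

Measured so far in a functional assay on NCI/ADR-RES cells (Homo sapiens) for antiproliferative activity, read by MTT assay, with a stated time of 48 h; on this read-out lower numbers stand for stronger inhibition and higher numbers for weaker inhibition:
- compound 1 `C=C1[C@H](O)[C@@H](O)[C@@H](O)C(C)(C)/C=C/[C@H](C)[C@H](OC(=O)c2ccccc2)[C@@]2(O)C[C@@](C)(O)[C@H](OC(C)=O)[C@@H]2[C@H]1OCC(C)C` gives > 100000 nM as a limit
- compound 2 `C=C1[C@H](O)[C@@H](OC(=O)C(C)(C)C)[C@@H](O)C(C)(C)/C=C/[C@H](C)[C@H](OC(=O)c2ccccc2)[C@@]2(O)C[C@@](C)(O)[C@H](OC(C)=O)[C@@H]2[C@H]1OCC(C)C` gives > 100000 nM as a limit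

Within the data shown here, compound 2 has no number, only a limit, and the series so far shows the limit of > 100000 nM in this assay, at which 2 of the 2 values shown sit, and nothing else. Compound 3 `C=C1[C@H](O)[C@@H](OC(=O)c2cccc(C)c2)[C@@H](O)C(C)(C)/C=C/[C@H](C)[C@H](OC(=O)c2ccccc2)[C@@]2(O)C[C@@](C)(O)[C@H](OC(C)=O)[C@@H]2[C@H]1OCC(C)C` carries 3-methylphenyl in place of tert-butyl on a carbonyl carbon. Among the measured compounds shown here, the only measured step bearing on this is a step that the two limits leave unreadable from compound 1 to compound 2 and it offers no size to carry over. The estimated step is an at least 1.2-fold lower number from compound 2 to compound 3 (0.09 log units; that floor lies within the scatter) and any movement is expected towards stronger inhibition. Compound 3 is estimated at 80000 nM with an expected range of 30000 nM to 100000 nM and may again return only a limit.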

Compound 3, half-maximal inhibitory concentration: 75200 nM
The estimate for compound 3 lay 1.1-fold (0.03 log units) above the measured number; the range from low to high includes it.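

In this assay, compound 3 is the only compound shown with a number rather than a limit, so an aromatic ring on this carbonyl carbon gives the position its first readable steps. These are an at least 1.3-fold lower number from compound 2 to compound 3 (0.12 log units; that floor lies within the scatter) and, against hydrogen on that oxygen, an at least 1.3-fold lower number from compound 1 to compound 3 (0.12 log units; that floor lies within the scatter). The step between the other two compounds cannot be read, and both readable steps rest on a limit: the limit of > 100000 nM in this assay, at which 2 of the 3 values shown sit.

From the compounds shown here alone, whether this position can carry inhibition beyond the scatter remains open. An amine or a longer chain in place of 3-methylphenyl on the carbonyl carbon would test this.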